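From propyl to isopropyl, with only limits in hand

The compounds below may be only part of what the source reports. "The series", "measured", "known", "first", "only" and "open" are said of these compounds alone.

In a toxicity assay on HT-29 cells (Homo sapiens) for cytotoxicity (on this read-out higher numbers stand for lower toxicity in this test and lower numbers for higher toxicity in this test), compound 3 `CCCn1nc(C(=O)N[C@H]2COc3ccccc3N(C)C2=S)nc1Cc1ccccc1` gives > 100000 nM as a limit and not as a number. Compound 2 `CCn1nc(C(=O)N[C@H]2COc3ccccc3N(C)C2=S)nc1Cc1ccccc1` gives > 100000 nM as a limit too. Compound 1 `CN1C(=S)[C@@H](NC(=O)c2n[nH]c(Cc3ccccc3)n2)COc2ccccc21` gives > 50000 nM as a limit as well, and it has hydrogen on the aromatic nitrogen that carries the chain in the other two.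

Compound 4 `CC(C)n1nc(C(=O)N[C@H]2COc3ccccc3N(C)C2=S)nc1Cc1ccccc1` is reached through isopropyl in place of propyl on an aromatic nitrogen in which isopropyl stands in place of propyl on an aromatic nitrogen. Among the measured compounds shown here, three measured steps bear on this change. The step that the two limits leave unreadable from compound 1 to compound 2 and the step that the two limits leave unreadable from compound 1 to compound 3 both put a chain on that nitrogen, and the step that the two limits leave unreadable from compound 2 to compound 3 adds methyl to that chain. None of the three has a readable size, and none gives a direction.

Compound 3 stands at > 100000 nM as a limit, and compound 4 is expected to stay in the same region. No change beyond the usual scatter is expected in this assay and the expected outcome is a number no higher from compound 3 to compound 4 (the limit leaves the size open) in no set direction. The estimate for compound 4 is 100000 nM with an expected range from 40000 nM to 250000 nM and a report as a limit is the likeliest result.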

Compound 4, half-maximal cytotoxic concentration: > 100000 nM
Compound 4: no number, only a limit (the forecaster's own chance of this, stated with the estimate: 85%); the middle value lies on the limit itself.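

In this assay compound 4 gives > 100000 nM, a limit and not a number. Compound 3 gives > 100000 nM, also a limit. Among the compounds shown here, no step from compound 1, compound 2 or compound 3 to compound 4 can be read. The compounds shown leave open whether propyl, isopropyl or any other chain on that aromatic nitrogen changes the read-out at all, in size or in direction.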